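This account rests on a few compounds, and the source may have more. Where it says the series, first, only, none or still open, it means among the compounds named here.

Measured in a functional assay on NCI-H1993 cells (Homo sapiens) for inhibition, read by CCK-8 assay, with a stated time of 72 h; on this read-out lower numbers stand for stronger inhibition and higher numbers for weaker inhibition:
Compound 1 `COC(=O)c1ccc(-c2cnc3ncn(C(C)c4cc5cccnc5cc4F)c3n2)cc1F`: 60.2 nM
Compound 2 `CC(NC/N=C/c1cn[nH]c1)c1ccc2ncccc2c1`: 519 nM

Going by the values given here, only these two compounds have numbers so far, and they do not differ in one place, so no single change can be read from them. Compound 2 stands at the higher of the two numbers, at 519 nM, which makes it the weaker inhibitor. Compound 1 gives 60.2 nM, and that gap lies beyond the usual scatter.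

The next compound to be tested is compound 3 `CC(NC/N=C/c1ccccc1)c1ccc2ncccc2c1`. It keeps the rest of compound 2 and carries phenyl in place of 1H-pyrazol-4-yl on a carbon with a double bond to nitrogen. Among the compounds with values here, no measured step shows what this exchange does, so the expectation rests on the structural change alone and is loose. In this assay a moderate move towards weaker inhibition is expected, modestly beyond the scatter. The expected change is a 2.9-fold higher number from compound 2 to compound 3 (0.46 log units; beyond the scatter). The estimate for compound 3 is 1500 nM, with an expected range from 350 nM to 6500 nM.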

Compound 3, half-maximal inhibitory concentration: 1220 nM
Compound 3: middle estimate off by 1.2-fold (0.09 log units), on the high side, within the range that was stated.
By their numbers in this assay, from the lowest: compound 1; then compound 2; then compound 3.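

In this assay, going by these compounds alone, phenyl in place of 1H-pyrazol-4-yl on a carbon with a double bond to nitrogen gives a 2.4-fold higher number from compound 2 to compound 3 (0.37 log units; beyond the scatter), which is the first single change that can be read, and it moves the number modestly towards weaker inhibition. The position therefore accepts a six-membered aromatic ring of carbon only, with no hydrogen-bond donor or acceptor, and compound 3 still gives a measurable 1220 nM, so inhibition is weakened by this exchange but not lost. Nothing at hand explains why the number rises with this exchange.

The compounds shown leave open whether the ring nitrogens of 1H-pyrazol-4-yl matter here, since a single step cannot separate them from the change in ring size, and pyridin-4-yl or imidazol-4-yl at the same place would speak to that more directly. From the compounds shown here alone, it also remains open how the phenyl of compound 3 would respond to a substituent such as an amine or a carboxylic acid, and whether this step would have the same size on another core.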